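The compounds below may be only part of what the source reports. "The series", "measured", "known", "first", "only" and "open" are said of these compounds alone.

Measured compounds: compound 1 `N/C(=N/NC(CC(=O)c1ccc(-n2ccnc2)cc1)c1cccc(F)c1)c1ccccn1` gives 26500 nM in an ADME assay on Vero cells (Chlorocebus sabaeus) for cytotoxicity, read by MTT assay, with a stated time of 72 h; a higher number here means that more compound is tolerated, a lower number that less compound is tolerated; compound 2 `N/C(=N/NC(CC(=O)c1ccc(-n2ccnc2)cc1)c1cccc([N+](=O)[O-])c1)c1ccccn1` gives 28700 nM in this assay; compound 3 `N/C(=N/NC(CC(=O)c1ccc(-n2ccnc2)cc1)c1cccc(Cl)c1)c1ccccn1` gives 68600 nM in this assay.

Compound 3 stands highest of the measured compounds: the step of a 2.4-fold higher number from compound 2 to compound 3 (0.38 log units; beyond the scatter) and the step of a 2.6-fold higher number from compound 1 to compound 3 (0.41 log units; beyond the scatter) both run beyond the scatter, so more of compound 3 is tolerated than of either other compound. Compound 4 `N/C(=N/NC(CC(=O)c1ccc(-n2ccnc2)cc1)c1ccccc1Br)c1ccccn1` differs from compound 3 by 2-bromophenyl in place of 3-chlorophenyl on a saturated chain carbon bound to an amine nitrogen and a saturated chain carbon. Among the compounds with values here, the measured steps swap only the substituent at the same place on that ring, and each brought a modest rise; no step swaps halogen and group together as here. The new bromo compound is expected to stay near compound 3, with the step of a 1.2-fold lower number from compound 3 to compound 4 (0.10 log units; within the scatter) within the scatter. Compound 4 is therefore estimated at 55000 nM, between 22000 nM and 130000 nM.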

Compound 4, half-maximal cytotoxic concentration: 29000 nM
Compound 4: middle estimate off by 1.9-fold (0.28 log units), on the high side; the range from low to high includes it.
By their numbers in this assay, from the lowest: compounds 1, 2 and 4 (each within the scatter of the next); then compound 3.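

In this assay, putting 2-bromophenyl in place of 3-chlorophenyl on this saturated chain carbon gives a clear change (a 2.4-fold lower number from compound 3 to compound 4 (0.37 log units; beyond the scatter)), so the higher number of compound 3 does not carry over to this other halogen-bearing ring. The steps (a 1.0-fold higher number from compound 2 to compound 4 (0.00 log units; within the scatter)) and (a 1.1-fold higher number from compound 1 to compound 4 (0.04 log units; within the scatter)) lie within the scatter, leaving compound 3 alone apart from the other three. Nothing measured here gives a reason for this. Since halogen and its place on the ring changed together, 3-bromophenyl or 2-chlorophenyl would be needed to separate the two. Going by these compounds, how a phenyl ring carrying an amine or a carboxylic acid would behave also stays open.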